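This account rests on a few compounds, and the source may have more. Where it says the series, first, only, none or still open, it means among the compounds named here.

Measured compounds in a functional assay on A549 cells (Homo sapiens) for antiproliferative activity, read by MTT assay, with a stated time of 72 h; a higher number here means a weaker inhibitor, a lower number a stronger inhibitor:

compound 1 `COc1cc2ncnc(N3CCc4ccccc43)c2cc1NC(=O)C=C(C)C`: 6270 nM
compound 2 `CCC/C=C/C(=O)Nc1cc2c(N3CCc4ccccc43)ncnc2cc1OC`: 2920 nM

Within the data shown here, compound 2 holds the lower of the two numbers in this assay, with compound 1 as its only neighbour; the step of a 2.1-fold lower number from compound 1 to compound 2 (0.33 log units; beyond the scatter) is a change at the end of the unsaturated acyl chain on the amide nitrogen, and it is modest.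

Compound 3 `COc1cc2ncnc(N3CCc4ccccc43)c2cc1NC(=O)/C=C/CN1CCCCC1` is the next compound in the series and is not yet measured. Relative to compound 2 the change is piperidin-1-yl in place of ethyl on a saturated chain carbon bound to a double-bonded chain carbon. This again alters only the outer part of the acyl chain, leaving the shared core and the amide itself untouched.

Among the measured compounds shown here, the one measured step, a 2.1-fold lower number from compound 1 to compound 2 (0.33 log units; beyond the scatter), is the only guide and it concerns the same region, though it exchanges one hydrocarbon chain for another rather than bringing in a ring with a nitrogen. For the measured compounds named here, no measured step covers the entry of piperidin-1-yl. A step of modest size, most likely towards a lower number, is therefore expected, with wide uncertainty; the estimate for compound 3 is 1500 nM, range 400 nM to 6000 nM, corresponding to a 1.9-fold lower number from compound 2 to compound 3 (0.29 log units; within the scatter).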

Compound 3, half-maximal inhibitory concentration: 2540 nM
Estimate against measurement, compound 3: 1.7-fold (0.23 log units) below; the range from low to high includes it.
By their numbers in this assay, from the lowest: compounds 3 and 2 (each within the scatter of the next); then compound 1.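

In this assay, a 1.1-fold lower number from compound 2 to compound 3 (0.06 log units; within the scatter) comes with piperidin-1-yl in place of ethyl on a saturated chain carbon bound to a double-bonded chain carbon, so this position accepts a six-membered ring with a nitrogen without a readable shift from the hydrocarbon chain of compound 2. Measured against compound 1, the new chain gives a 2.5-fold lower number from compound 1 to compound 3 (0.39 log units; beyond the scatter) in the same assay, so both unbranched-at-the-end chains, 3-(piperidin-1-yl)prop-1-en-1-yl and pent-1-en-1-yl, stand apart from the 2-methylprop-1-en-1-yl group, each by a modest step, while compounds 2 and 3 cannot be told apart. No measurement at hand speaks to what lies behind these numbers.

As far as these compounds go, whether an open-chain amine such as dimethylamino, or a ring with a second hetero atom such as morpholin-4-yl, on the same saturated chain carbon would separate from piperidin-1-yl remains open, as does the effect of a carboxylic acid or a longer chain there. From the compounds shown here alone, the three compounds also share one core and one methoxy group, so whether the flat response at this position holds with a different group on the core is unknown.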